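The source may hold more compounds than are shown below. What is called first, only, known or untested is meant among the compounds shown, and "the series" means these compounds.

The measured compounds are:
compound 1, `COc1cc(N(C)CCN(C)C)c(NC(=O)/C=C\C(C)C)cc1Nc1ncc(C#N)c(-c2cn(C)c3ccccc23)n1`, 1110 nM;
compound 2, `CCC/C=C\C(=O)Nc1cc(Nc2ncc(C#N)c(-c3cn(C)c4ccccc34)n2)c(OC)cc1N(C)CCN(C)C`, 823 nM;
compound 3, `COc1cc(N(C)CCN(C)C)c(NC(=O)/C=C\C(C)C)cc1Nc1nc(C)cc(-c2cn(C)c3ccc(F)cc23)n1`, 8520 nM.

All three numbers come from a functional assay on NCI-H1975 cells (Homo sapiens) for antiproliferative activity, read by MTT assay, with a stated time of 72 h; on this read-out lower numbers stand for stronger inhibition and higher numbers for weaker inhibition. Compound 2 differs from compound 1 by a single change, (propyl in place of isopropyl on a double-bonded chain carbon bound to a double-bonded chain carbon), and in this assay that change gave a 1.3-fold lower number from compound 1 to compound 2 (0.13 log units; within the scatter). Compound 3 carries a different core from compound 1; the difference between the two cores is not broken down here, and in this assay compound 3 gives a higher number than either of the other two. Compound 4, `CCC/C=C\C(=O)Nc1cc(Nc2nc(C)cc(-c3cn(C)c4ccc(F)cc34)n2)c(OC)cc1N(C)CCN(C)C`, has not yet been measured. It differs from compound 3 by propyl in place of isopropyl on a double-bonded chain carbon bound to a double-bonded chain carbon, the same change, at the same place, that took compound 1 to compound 2. Resting on a 1.3-fold lower number from compound 1 to compound 2 (0.13 log units; within the scatter), a similarly small step is expected for compound 4: a 1.4-fold lower number from compound 3 to compound 4 (0.13 log units; within the scatter). For compound 4 in this assay the estimate is 6300 nM, expected to fall between 3000 nM and 13000 nM.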

Compound 4, half-maximal inhibitory concentration: 12200 nM
The estimate for compound 4 lay 1.9-fold (0.29 log units) below the measured number, and the stated range covers the measured number.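

In this assay, putting propyl in place of isopropyl gave a 1.4-fold higher number from compound 3 to compound 4 (0.16 log units; within the scatter). Set beside the same change on the core of compound 1, this step does not differ by more than repeated measurements would: the same change on two cores in this assay, a 1.3-fold lower number (0.13 log units; within the scatter) from compound 1 to compound 2 and a 1.4-fold higher number (0.16 log units; within the scatter) from compound 3 to compound 4, 1.9-fold (0.29 log units) apart, within the scatter of two such steps. On these two cores, then, the change stays a small step that cannot be told from scatter, but two pairs cannot show that this holds on other cores, nor rule out a slight real difference between these two.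

As far as these compounds go, whether a longer chain such as butyl, or a cyclopropyl ring, at this place would move the number beyond the scatter remains open. So does the effect of an amine on this chain on either core.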